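The source may report more compounds than this note shows. Statements on the series, on what has been measured and on what is new or still open speak of the compounds shown alone.

Among the measured compounds shown here, compound 2 `CCN(CC)c1ccc2cc(C(=O)c3ccc(N4CCN(C(=O)CN5CCN(S(=O)(=O)c6ccc(C#N)cc6)CC5)CC4)cc3)oc2c1` gives the only number in this set: in a functional assay on HCT-116 cells (Homo sapiens) for cytotoxicity, read by MTT assay, with a stated time of 48 h (on this read-out lower numbers stand for stronger inhibition and higher numbers for weaker inhibition), compound 2 gives 36400 nM. Compound 1 `CCN(CC)c1ccc2cc(C(=O)c3ccc(N4CCN(C(=O)CN5CCN(S(=O)(=O)C6CC6)CC5)CC4)cc3)oc2c1` is known in this assay only as a limit, > 40000 nM. Compound 3 `C#CCN1CCN(CC(=O)N2CCN(c3ccc(C(=O)c4cc5ccc(N(CC)CC)cc5o4)cc3)CC2)CC1` differs from compound 2 by propargyl in place of (4-cyanophenyl)sulfonyl on an amine nitrogen in a ring. For the measured compounds named here, the one measured step, an at least 1.0-fold lower number from compound 1 to compound 2 (0.04 log units; that floor lies within the scatter), touched the sulfonyl group alone and bears only loosely on the loss of the whole sulfonyl unit; it gives no direction for a step beyond the scatter, and the nearby limit of > 40000 nM in this assay, at which 1 of the 2 values shown sits, makes a bare limit plausible for compound 3. Compound 3 is therefore expected near 30000 nM, within 8000 nM to 80000 nM, a step of a 1.2-fold lower number from compound 2 to compound 3 (0.08 log units; within the scatter).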

Compound 3, half-maximal inhibitory concentration: 17700 nM
Compound 3: middle estimate off by 1.7-fold (0.23 log units), on the high side, and the stated range covers the measured number.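

In this assay, among the compounds shown here, the ring nitrogen does not need a sulfonyl unit: propargyl in place of (4-cyanophenyl)sulfonyl gives a 2.1-fold lower number from compound 2 to compound 3 (0.31 log units; beyond the scatter) and is the first step here beyond the scatter. Propargyl in place of cyclopropylsulfonyl likewise gives an at least 2.2-fold lower number from compound 1 to compound 3 (0.35 log units; beyond the scatter) on the same nitrogen. The value of compound 1 is a limit, so this second step has only a floor. The compounds shown leave open whether a methyl, an acetyl group or a free secondary amine on this nitrogen would do the same as propargyl, and so whether the triple bond counts at all.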